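The source may hold more compounds than are shown below. What is called first, only, known or untested is meant among the compounds shown, and "the series" means these compounds.

In a functional assay on MDA-MB-436 cells (Homo sapiens) for antiproliferative activity, read by MTT assay, with a stated time of 48 h; on this read-out lower numbers stand for stronger inhibition and higher numbers for weaker inhibition:
Compound 1 `C=CS(=O)(=O)N1CCN(c2ncnc3sc(-c4ccc(OC)nc4)cc23)CC1`: 11900 nM
Compound 2 `C=CS(=O)(=O)N1CCN(c2nc(OC[C@H]3CCCN3C)nc3sc(-c4ccc(N5CCN(C)CC5)cc4)cc23)[C@@H](C)C1`: 1920 nM
Compound 3 `CN1CCN(c2ccc(-c3cc4c(N5CCN(S(=O)(=O)C6CC6)CC5)ncnc4s3)cc2)CC1`: 10600 nM

Compound 3 stands level with compound 1, within the usual scatter, while compound 2 gives a lower number, beyond that scatter. Compound 4 `CN1CCN(c2ccc(-c3cc4c(N5CCN(C(=O)Nc6ccc(C#N)cc6)CC5)ncnc4s3)cc2)CC1` carries (4-cyanophenyl)carbamoyl in place of cyclopropylsulfonyl on an amine nitrogen in a ring. Among the compounds with values here, no two measured compounds differ in one place alone, so nothing here measures this change directly. A small move towards a lower number in this assay is therefore only a cautious expectation. The estimated change is a 2.1-fold lower number from compound 3 to compound 4 (0.33 log units; beyond the scatter). For compound 4 the expected value is 5000 nM, with an estimated range of 1500 nM to 17000 nM.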

Compound 4, half-maximal inhibitory concentration: 5010 nM
Compound 4: middle estimate off by 1.0-fold (0.00 log units), on the low side; low and high end bracket the measured number.
By their numbers in this assay, from the lowest: compound 2; then compound 4; then compounds 3 and 1 (each within the scatter of the next).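

In this assay the one-place exchange of cyclopropylsulfonyl for (4-cyanophenyl)carbamoyl gives a 2.1-fold lower number from compound 3 to compound 4 (0.33 log units; beyond the scatter) and this is a modest step beyond the scatter. Within the data shown here, it is the first sign that the group on this ring amine nitrogen can shift the number. No evidence here accounts for the step. Still open, from the compounds shown here alone, is whether the carbamoyl link or the 4-cyanophenyl ring matters more. An acetyl group, or a phenylcarbamoyl without the nitrile, on the same nitrogen would help separate the two.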